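Swapping a Triazole for an Imidazole: Clearance Outlook

The compounds below may be only part of what the source reports. "The series", "measured", "known", "first", "only" and "open" are said of these compounds alone.

Measured so far:
- compound 1, `COc1cc(N2CCN(C(=O)CN3CCc4ccccc43)CC2)ccc1-c1cnc(C)o1`, 160 mL.min-1.g-1
- compound 2, `COc1cc(N2CCN(C(=O)N[C@@H](C)c3cccc4ccccc34)CC2)ccc1-n1cc(C)nn1`, 230 mL.min-1.g-1
- compound 3, `COc1cc(N2CCN(C(=O)NCc3cccc4ccccc34)CC2)ccc1-c1cnc(C)o1`, 160 mL.min-1.g-1

All three compounds were run in an ADME assay on microsomes from liver (Rattus norvegicus) for metabolic stability, read by LC-MS; on this read-out lower numbers stand for slow clearance and higher numbers for fast clearance. Compound 2 carries the highest of the three numbers, yet compound 1 and compound 3 each lie within the usual scatter of it, so the three cannot be told apart with confidence. Compound 4, `COc1cc(N2CCN(C(=O)N[C@@H](C)c3cccc4ccccc34)CC2)ccc1-n1cnc(C)c1`, is not yet measured. It differs from compound 2 in one place: 4-methyl-1H-imidazol-1-yl in place of 4-methyl-1H-1,2,3-triazol-1-yl on an aromatic carbon. Within the data shown here, no two measured compounds differ in a single place, so there is no earlier step to lean on. The estimated change, no change at the digits printed from compound 2 to compound 4 (within the scatter), is expected to be none beyond the scatter in this assay. Compound 4 is therefore expected to give 230 mL.min-1.g-1 in this assay, between 110 mL.min-1.g-1 and 480 mL.min-1.g-1.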

Compound 4, intrinsic clearance in microsomes: 150 mL.min-1.g-1
Compound 4: middle estimate off by 1.5-fold (0.19 log units), on the high side; the measured number falls inside the stated range.
By their numbers in this assay, from the lowest: compounds 4, 1, 3 and 2 (each within the scatter of the next).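

In this assay the change to 4-methyl-1H-imidazol-1-yl in place of 4-methyl-1H-1,2,3-triazol-1-yl gives a 1.5-fold lower number from compound 2 to compound 4 (0.19 log units; within the scatter). Among these compounds, this is the first change in a single place in the set, and it shows that, on this aromatic carbon ortho to a methoxy group, a ring with 3 hetero atoms can give way to one with 2 without a shift that stands clear of the scatter. Nothing at hand bears on what sets clearance at this position. Going by these compounds, what an amine or a carboxylic acid on this carbon would do to the number stays open.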